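A few compounds are considered here, and "the series" means these few. Any claim that something is new, unique, unknown or untested is made for them only; others in the source may bear on it.

Among the compounds with values here, compound 3 `Cc1cc(C)cc(S(=O)(=O)c2c(C(=O)NCc3ccc4nc(N)[nH]c4c3)[nH]c3ccc(Cl)cc23)c1` gives 5890 nM in an ADME assay on MT4 cells (Homo sapiens) for cytotoxicity, read by MTT assay (on this read-out higher numbers stand for lower toxicity in this test and lower numbers for higher toxicity in this test), the lowest of the two numbers known there. Compound 1 `Cc1cc(C)cc(S(=O)(=O)c2c(C(=O)NC(C)C(=O)NCc3ccccc3F)[nH]c3ccc(Cl)cc23)c1` gives 23300 nM in this assay. Compound 2 `Cc1cc(C)cc(S(=O)(=O)c2c(C(=O)NCc3cccc(F)c3F)[nH]c3ccc(Cl)cc23)c1` reaches only a limit of > 51100 nM in this assay. Within the data shown here, the one measured step, an at least 8.6-fold lower number from compound 2 to compound 3 (0.93 log units; beyond the scatter), rests on that limit of > 51100 nM in this assay, at which 1 of the 3 values shown sits, and so marks a lower bound on its size. Compound 4 `Cc1cc(C)cc(S(=O)(=O)c2c(C(=O)Nc3ccnc(C#N)c3)[nH]c3ccc(Cl)cc23)c1` differs from compound 3 by a group of 8 heavy atoms (6 carbon, 2 nitrogen; one six-membered aromatic ring with 1 hetero atom) in place of a group of 11 heavy atoms (8 carbon, 3 nitrogen; one five-membered aromatic ring with 2 hetero atoms, one six-membered aromatic ring of carbon only), on an amide-type nitrogen. Among the measured compounds shown here, no measured step covers this exact change, but both compounds that lack the 2-amino-1H-benzimidazol-6-yl sit higher than compound 3, so compound 4 is expected to move upward in this assay. The step expected is a 3.4-fold higher number from compound 3 to compound 4 (0.53 log units; beyond the scatter). Compound 4 is estimated at 20000 nM, between 6000 nM and 60000 nM.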

Compound 4, half-maximal cytotoxic concentration: 6840 nM
Compound 4: the middle estimate sits 2.9-fold (0.47 log units) above what was measured; measured number inside the range.
By their numbers in this assay, from the lowest: compounds 3 and 4 (each within the scatter of the next); then compound 1. At a limit, above all of these: compound 2.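

On the amide-type nitrogen, 2-cyanopyridin-4-yl in place of the larger group gives a 1.2-fold higher number from compound 3 to compound 4 (0.06 log units; within the scatter) in this assay, so a number this far down does not need the 2-amino-1H-benzimidazol-6-yl group. In place of 2,3-difluorobenzyl on that nitrogen, the same group gives an at least 7.4-fold lower number from compound 2 to compound 4 (0.87 log units; beyond the scatter). The size of that step is only a lower bound, as compound 2 stands at a limit: the limit of > 51100 nM in this assay, at which 1 of the 4 values shown sits. The compounds shown leave open whether a plain pyridin-4-yl, without the nitrile, would give a similar number. They also leave open what an aminomethyl group in the nitrile's place would do.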